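The source may report more compounds than this note shows. Statements on the series, on what has been measured and on what is new or still open speak of the compounds shown alone.

Measured so far:
compound 1 `CCC1(Cc2ccccc2)OS(=O)(=O)C=C1OC` — > 400000 nM
compound 2 `CCC1(Cc2ccccc2)OS(=O)(=O)C=C1OCC1CCCCC1` — >= 200000 nM

In an ADME assay on HEL cells (Homo sapiens) for cytotoxicity, with a stated time of 3 days (on this read-out lower numbers stand for higher toxicity in this test and higher numbers for lower toxicity in this test), compound 2 gives >= 200000 nM, a limit of the test and not a number. Compound 1 likewise gives only a limit, > 400000 nM. The step that the two limits leave unreadable from compound 1 to compound 2 is therefore unreadable. Compound 3 `CCC1(Cc2ccccc2)OS(=O)(=O)C=C1OCc1ccc(Cl)cc1` differs from compound 2 by 4-chlorophenyl in place of cyclohexyl on a saturated chain carbon bound to an oxygen on an unsaturated carbon. For the measured compounds named here, no measured step bears on this change; the two recorded values are both limits, so the expected step is a number no higher from compound 2 to compound 3 (the limit leaves the size open), within the scatter. Compound 3 is expected at 200000 nM, between 100000 nM and 400000 nM, most likely again reported as a limit.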

Compound 3, minimum cytotoxic concentration: >= 50000 nM
Compound 3 was reported as a limit; the forecaster's own chance of this, stated with the estimate: 85%; the middle value lies beyond the limit too.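

In this assay, for the compounds shown here, compound 1, compound 2 and compound 3 are all reported as limits and not numbers, and no step among them can be read. Left open is whether 4-chlorophenyl in place of cyclohexyl changes the read-out at all.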